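The source may report more compounds than this note shows. Statements on the series, on what has been measured and on what is new or still open speak of the compounds shown alone.

Measured compounds in a functional assay on A-375 cells (Homo sapiens) for antiproliferative activity, read by MTT assay, with a stated time of 48 h; on this read-out lower numbers stand for stronger inhibition of growth and higher numbers for weaker inhibition of growth:
- compound 1 `FC(F)(F)c1ccc(C2=NN(C(=S)Nc3ccccc3)C(c3ccc4c(c3)OCCO4)C2)cc1`, 43500 nM
- compound 2 `O=[N+]([O-])c1ccc(C2=NN(C(=S)Nc3ccccc3)C(c3ccc4c(c3)OCCO4)C2)cc1`, 78100 nM
- compound 3 `COc1cccc(C2=NN(C(=S)Nc3ccccc3)C(c3ccc4c(c3)OCCO4)C2)c1`, 520 nM

Compound 3 holds the lowest number of the three in this assay: an 84-fold lower number from compound 1 to compound 3 (1.92 log units; beyond the scatter) and a 150-fold lower number from compound 2 to compound 3 (2.18 log units; beyond the scatter) are both large and beyond the scatter, whereas a 1.8-fold higher number from compound 1 to compound 2 (0.25 log units; within the scatter) is within it. Both large steps exchange the whole aryl group on the ring carbon with a double bond to nitrogen and both end at compound 3.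

Compound 4 `Cc1ccc(C2=NN(C(=S)Nc3ccccc3)C(c3ccc4c(c3)OCCO4)C2)cc1C` differs from compound 3 as follows: 3,4-dimethylphenyl in place of 3-methoxyphenyl on a carbon with a double bond to nitrogen. The measured steps bear on it only in that they show the group at this position to move this assay by large amounts. Among the measured compounds shown here, no measured step exchanges the 3-methoxyphenyl for an aryl group carrying only methyl groups, so neither direction nor size is fixed by the data. The expected step is a 7.7-fold higher number from compound 3 to compound 4 (0.89 log units; beyond the scatter), upward but smaller than the steps separating compound 3 from compounds 1 and 2. For compound 4 the estimate in this assay is 4000 nM, with a range from 700 nM to 25000 nM.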

Compound 4, concentration for 50% growth inhibition: 61300 nM
Compound 4: the middle estimate sits 15-fold (1.19 log units) below what was measured; measured number outside the range, above it.
By their numbers in this assay, from the lowest: compound 3; then compounds 1, 4 and 2 (each within the scatter of the next).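

In this assay, the exchange of 3-methoxyphenyl for 3,4-dimethylphenyl gives a 120-fold higher number from compound 3 to compound 4 (2.07 log units; beyond the scatter), so the large gap at this position is not confined to the aryl groups bearing trifluoromethyl or nitro. The other two steps, a 1.4-fold higher number from compound 1 to compound 4 (0.15 log units; within the scatter) and a 1.3-fold lower number from compound 2 to compound 4 (0.11 log units; within the scatter), leave these three aryl groups unseparated, and among the four compounds only the 3-methoxyphenyl of compound 3 stands apart. Nothing available accounts for this separation.

As far as these compounds go, whether a hydroxyl or an amino group in place of the methoxy of compound 3 would keep a number close to that of compound 3 remains open. So does whether the 3-methoxyphenyl would keep its standing with a morpholine ring in place of the 2,3-dihydro-1,4-benzodioxin-6-yl group.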